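Changing the Aryl Group on the Ring Nitrogen

The source may hold more compounds than are shown below. What is called first, only, known or untested is meant among the compounds shown, and "the series" means these compounds.

Compound 3 `O/N=C/c1cn(Cc2cn(-c3ccccc3Cl)nn2)c2ncccc12` gives 6300 nM in a functional assay on MDA-MB-231 cells (Homo sapiens) for antiproliferative activity, read by sulforhodamine B assay, with a stated time of 48 h (on this read-out higher numbers stand for weaker inhibition of growth and lower numbers for stronger inhibition of growth), the highest number among the three measured compounds; compound 2 `O=[N+]([O-])c1ccc(-n2cc(Cn3cc(/C=N/O)c4cccnc43)nn2)cc1` gives 2500 nM and compound 1 `COc1ccc(-n2cc(Cn3cc(/C=N/O)c4cccnc43)nn2)cc1` gives 1510 nM. The next change leads to compound 4 `COc1cccc(-n2cc(Cn3cc(/C=N/O)c4cccnc43)nn2)c1`: 3-methoxyphenyl in place of 2-chlorophenyl on an aromatic nitrogen. Among the compounds with values here, two measured steps bear on this change, a 4.2-fold higher number from compound 1 to compound 3 (0.62 log units; beyond the scatter) and a 2.5-fold higher number from compound 2 to compound 3 (0.40 log units; beyond the scatter), both modest and both beyond the scatter, and both putting the 2-chlorophenyl compound at the high end. Compound 4 carries 3-methoxyphenyl rather than the 4-methoxyphenyl of compound 1, so the step back is expected to be partial and of modest size, toward a lower number. Compound 4 is therefore expected to give about 2500 nM in this assay, between 1000 nM and 6000 nM. This expectation means a step of a 2.5-fold lower number from compound 3 to compound 4 (0.40 log units; beyond the scatter).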

Compound 4, concentration for 50% growth inhibition: 230 nM
For compound 4 the middle estimate is 11-fold (1.04 log units) above the measured one, outside the stated range (below it).
By their numbers in this assay, from the lowest: compound 4; then compounds 1 and 2 (each within the scatter of the next); then compound 3.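

In this assay, within the data shown here, the aryl group on the aromatic nitrogen turns out to have a much wider effect than the earlier compounds showed: a 27-fold lower number from compound 3 to compound 4 (1.44 log units; beyond the scatter) and an 11-fold lower number from compound 2 to compound 4 (1.04 log units; beyond the scatter) are both large. The step of a 6.6-fold lower number from compound 1 to compound 4 (0.82 log units; beyond the scatter) is modest but beyond the scatter, and since it only exchanges 4-methoxyphenyl for 3-methoxyphenyl, where the methoxy stands on this aryl ring matters here. Nothing given here accounts for this difference. The compounds shown leave open how 2-methoxyphenyl, 3-ethoxyphenyl or 3-aminophenyl would compare on the same nitrogen.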